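Swapping the aryl group on a fused thiadiazole core

A few compounds are considered here, and "the series" means these few. Any claim that something is new, unique, unknown or untested is made for them only; others in the source may bear on it.

Compound 1 `COc1ccc2c(OCc3nnc4sc(-c5cc[nH]c5)nn34)ccnc2c1`: 353 nM
Compound 2 `COc1ccc2[nH]c(-c3nn4c(COc5ccnc6cc(OC)ccc56)nnc4s3)cc2c1`: 85.6 nM
Compound 3 `COc1ccc2c(OCc3nnc4sc(-c5cccc(F)c5)nn34)ccnc2c1`: 504 nM

Three compounds share one core and differ only in the group attached to an aromatic carbon of its five-membered ring. In a functional assay on EBC-1 cells (Homo sapiens) for antiproliferative activity, with a stated time of 72 h (a lower number here means a stronger inhibitor, a higher number a weaker inhibitor), compound 3 gives the highest number of the three. Its nearest neighbour is compound 1, reached by a 1.4-fold higher number from compound 1 to compound 3 (0.15 log units; within the scatter); its furthest is compound 2, reached by a 5.9-fold higher number from compound 2 to compound 3 (0.77 log units; beyond the scatter). The remaining comparison is a 4.1-fold lower number from compound 1 to compound 2 (0.62 log units; beyond the scatter).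

Compound 4 `COc1ccc2c(OCc3nnc4sc(-c5ccn(CC6CC6)c5)nn34)ccnc2c1` has not been measured. It differs from compound 3 in one place: 1-(cyclopropylmethyl)-1H-pyrrol-3-yl in place of 3-fluorophenyl on an aromatic carbon. The step that bears most directly on this change is a 1.4-fold higher number from compound 1 to compound 3 (0.15 log units; within the scatter): compound 4 carries the 1-(cyclopropylmethyl)-1H-pyrrol-3-yl group, whose pyrrole ring matches the 1H-pyrrol-3-yl of compound 1. For the measured compounds named here, no measured compound shows what a cyclopropylmethyl on that ring does. Given that the pyrrole-to-fluorophenyl step lay within the scatter, the step expected for compound 4 is a 1.4-fold lower number from compound 3 to compound 4 (0.16 log units; within the scatter), which may not reach beyond the scatter. For compound 4 the estimated value in this assay is 350 nM, with a range from 120 nM to 1000 nM.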

Compound 4, half-maximal inhibitory concentration: 351 nM
Beside the measured number, compound 4's estimate is 1.0-fold (0.00 log units) below it; low and high end bracket the measured number.
By their numbers in this assay, from the lowest: compound 2; then compounds 4, 1 and 3 (each within the scatter of the next).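

In this assay, for the compounds shown here, the new result gives the first reading of a substituent on the pyrrole nitrogen, and a 1.0-fold lower number from compound 1 to compound 4 (0.00 log units; within the scatter) shows that cyclopropylmethyl in place of hydrogen on that aromatic nitrogen leaves the number within the scatter. The comparison with the 3-fluorophenyl group gives a 1.4-fold lower number from compound 3 to compound 4 (0.16 log units; within the scatter) and so also stays within the scatter, which means that compound 1, compound 3 and compound 4 cannot be told apart at this position, while a 4.1-fold higher number from compound 2 to compound 4 (0.61 log units; beyond the scatter) keeps the 5-methoxy-1H-indol-2-yl group of compound 2 as the only one set apart, with the lowest number of the four. Nothing measured here offers a reason for either the flat result on the pyrrole nitrogen or the separate place of compound 2.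

As far as these compounds go, whether a smaller group such as methyl, a longer chain or a chain ending in an amine or a carboxylic acid on the pyrrole nitrogen would move the number beyond the scatter remains open. From the compounds shown here alone, it is also open whether the lower number of compound 2 would survive in a plain 1H-indol-2-yl group without the methoxy.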